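Flipping One Ring Stereocentre in a Prostacyclin Receptor Agonist Series

The compounds below may be only part of what the source reports. "The series", "measured", "known", "first", "only" and "open" are said of these compounds alone.

Measured so far:
compound 1, `O=C(O)CCC[C@H]1CC[C@@H]2[C@@H](/C=C/[C@@H](O)COc3ccccc3)[C@H](O)C[C@@H]2OC1`, > 10000 nM
compound 2, `O=C(O)CCCC[C@@H]1CC[C@@H]2[C@@H](/C=C/[C@@H](O)COc3ccccc3)[C@H](O)C[C@@H]2OC1`, > 10000 nM

In an ADME assay on CHO cells for agonist activity at prostacyclin receptor (Homo sapiens), read by HTRF and cAMP accumulation (on this read-out higher numbers stand for an effect only at larger amounts of compound and lower numbers for an effect already at smaller amounts), compound 1 reaches only the assay limit, > 10000 nM. Compound 2 likewise reaches only the limit, > 10000 nM. Both shown values sit at this limit, (the limit of > 10000 nM in this assay, at which 2 of the 2 values shown sit), so no step between measured compounds can be given.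

Compound 3 is `O=C(O)CCCC[C@H]1CC[C@@H]2[C@@H](/C=C/[C@@H](O)COc3ccccc3)[C@H](O)C[C@@H]2OC1`. It differs from compound 2 in that (the two compounds have the same atoms and bonds and differ only in configuration as drawn: 1 of 7 stereo elements differ; a stereocentre at a saturated ring carbon is drawn R in compound 2 and S in compound 3). Without a measured step, the expected change in this assay is guesswork: the estimated step that the limit leaves unreadable from compound 2 to compound 3 leans towards no shift beyond the scatter, with a chance that the flipped configuration unlocks activity. Compound 3 is therefore estimated at 15000 nM, within 1500 nM to 100000 nM.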

Compound 3, half-maximal effective concentration: > 10000 nM
Compound 3: only a limit was reported; the forecaster's own chance of this, stated with the estimate: 65%; the middle value lies beyond the limit too.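

Compound 1, compound 2 and compound 3 all reach only a limit, so no step to compound 3 can be read: the limit of > 10000 nM in this assay, at which 3 of the 3 values shown sit.

The compounds shown leave open whether any change to this structure would give a measurable effect in this assay.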